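Methyl tetrazole replaces methyl triazole on the sulfur

The source may report more compounds than this note shows. Statements on the series, on what has been measured and on what is new or still open speak of the compounds shown alone.

Three compounds have numbers in a functional assay on C6 cells (Rattus norvegicus) for cytotoxicity, read by MTT assay, with a stated time of 24 h, tested at 100 ug/mL; a higher number here means a weaker effect of the compound at the concentration tested, a lower number a stronger effect. Compound 1 `Cc1nnc(SCC(=O)N/N=c2/scc(-c3ccccc3)n2-c2ccccc2)s1` gives 61.8%, compound 2 `Cc1ccc(-c2cs/c(=N/NC(=O)CSc3nnnn3-c3ccccc3)n2-c2ccccc2)cc1` gives 28.5%, and compound 3 `Cc1ccc(-c2cs/c(=N/NC(=O)CSc3nncn3C)n2-c2ccccc2)cc1` gives 39.6%, the second highest of the three, beyond the scatter from both neighbours. Going by the values given here, the only single-point step known, a number 11.1 percentage points higher from compound 2 to compound 3 (beyond the scatter), was modest. Compound 4 `Cc1ccc(-c2cs/c(=N/NC(=O)CSc3nnnn3C)n2-c2ccccc2)cc1` is obtained from compound 3 through (1-methyl-1H-tetrazol-5-yl in place of 4-methyl-4H-1,2,4-triazol-3-yl on a sulfur). Among the compounds with values here, that step partly reverses the one from compound 2 to compound 3, since the tetrazole returns, but with a methyl rather than a phenyl on it, so the earlier step gives only weak guidance. Compound 4 is therefore expected to lie close to compound 3, with a number 3.6 percentage points lower from compound 3 to compound 4 (within the scatter) as the estimated shift, giving an expected 36% within 24% to 50%.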

Compound 4, a percentage reported as activity, at one concentration (the size of the read-out at that concentration, not a potency): 39.7%
For compound 4 the middle estimate is 3.7 percentage points below the measured one, within the range that was stated.
By their numbers in this assay, from the lowest: compound 2; then compounds 3 and 4 (each within the scatter of the next); then compound 1.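

In this assay, 1-methyl-1H-tetrazol-5-yl in place of 4-methyl-4H-1,2,4-triazol-3-yl on a sulfur gives a number 0.1 percentage points higher from compound 3 to compound 4 (within the scatter), so these two rings cannot be told apart here. With the tetrazole kept, methyl in place of phenyl on an aromatic nitrogen gives a number 11.2 percentage points higher from compound 2 to compound 4 (beyond the scatter), so the gap seen earlier goes with that exchange and not with the ring. Nothing available explains either step.
From the compounds shown here alone, it remains open whether a longer chain or a benzyl group on that aromatic nitrogen would read like methyl or like phenyl.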